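The source may report more compounds than this note shows. Statements on the series, on what has been measured and on what is new or still open speak of the compounds shown alone.

For the measured compounds named here, compound 3 `CN1CCN(C(=O)C2CCN(C(=O)c3ccc(S(C)(=O)=O)c([N+](=O)[O-])c3)CC2)CC1` is one of three compounds measured in an assay on isolated protein for inhibition of thyroid hormone receptor alpha (Homo sapiens), read by fluorescence polarization; on this read-out higher numbers stand for weaker inhibition and lower numbers for stronger inhibition. In this assay compound 3 gives > 60000 nM, which is a limit of the assay and not a number. Compound 1 `CS(=O)(=O)c1ccc(C(=O)N2CCC(C(=O)N3CCN(c4ccc(F)cc4)CC3)CC2)cc1[N+](=O)[O-]` gives > 60000 nM in this assay, again a limit rather than a number. Compound 2 `Cc1ccc(N2CCN(C(=O)C3CCN(C(=O)c4ccc(S(C)(=O)=O)c([N+](=O)[O-])c4)CC3)CC2)cc1` gives > 60000 nM, also a limit. All three sit together at one limit (the limit of > 60000 nM in this assay, at which 3 of the 3 values shown sit), so compound 3 stands level with the others without any readable difference among them.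

Compound 4 `CS(=O)(=O)c1ccc(C(=O)N2CCC(C(=O)N3CCN(c4ccccc4)CC3)CC2)cc1[N+](=O)[O-]` differs from compound 3 by phenyl in place of methyl on an amine nitrogen in a ring. The measured steps that bear on this change are a step that the two limits leave unreadable from compound 1 to compound 3 and a step that the two limits leave unreadable from compound 2 to compound 3; both are left unreadable by the limits, as is a step that the two limits leave unreadable from compound 1 to compound 2. Compound 1 and compound 2 carry a 4-fluorophenyl or a 4-methylphenyl at the same ring nitrogen and both gave only a limit; a phenyl at that position is therefore expected to behave the same way. The expected step is a step that the limit leaves unreadable from compound 3 to compound 4, which is to say nothing readable beyond the scatter. Compound 4 is accordingly expected to give 90000 nM in this assay, within a range of 25000 nM to 400000 nM, most probably reported once more as a limit.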

Compound 4, half-maximal inhibitory concentration: > 60000 nM
Compound 4: no number, only a limit; the forecaster's own chance of this, stated with the estimate: 85%; the middle value is on the limit's open side.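

Compound 4 adds no readable step in this assay: its steps to compound 1, compound 2 and compound 3 all run between limits and cannot be read, and the values are limits, not numbers: the limit of > 60000 nM in this assay, at which 4 of the 4 values shown sit.

The compounds shown leave open whether any group on the amine nitrogen in a ring, or any other change to the shared core, gives a readable value in this assay.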